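Ortho-Halogenated Benzyl Variation in an Orexin-1 Binding Series

This account rests on a few compounds, and the source may have more. Where it says the series, first, only, none or still open, it means among the compounds named here.

Measured compounds:
compound 1 `COc1ccc(N2C(=O)N(Cc3ccccc3)c3ccccc3S2(=O)=O)cc1OC` — 2000 nM
compound 2 `COc1cc(N2C(=O)N(Cc3c(F)cc(F)cc3F)c3ccccc3S2(=O)=O)cc(OC)n1` — 15.9 nM

In an assay on isolated protein for displacement of a labelled ligand from Orexin/Hypocretin receptor type 1 (Homo sapiens), with a stated time of 90 min (a lower number here means a stronger inhibitor, a higher number a weaker inhibitor), compound 1 gives 2000 nM, the higher of the two numbers recorded so far. Compound 2 gives 15.9 nM in this assay, a much lower number, but it differs from compound 1 in more than one place, so the two values alone do not single out which change carries the difference.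

Compound 3 `COc1ccc(N2C(=O)N(Cc3c(F)cccc3Cl)c3ccccc3S2(=O)=O)cc1OC` has not yet been measured. Relative to compound 1 the change is 2-chloro-6-fluorophenyl in place of phenyl on a saturated chain carbon bound to an amide-type nitrogen in a ring; the rest of the shared core is untouched. Among the compounds with values here, because the only measured comparison compound 2 gives 15.9 nM and also carries a halogen-bearing benzyl, the expectation is that compound 3 moves toward a lower number, with an estimated step of a 5.0-fold lower number from compound 1 to compound 3 (0.70 log units; beyond the scatter). Compound 3 is therefore expected near 400 nM, within a range of about 100 nM to 1500 nM.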

Compound 3, inhibition constant: 7.94 nM
Compound 3: middle estimate off by 50-fold (1.70 log units), on the high side, and the stated range ends above it.
By their numbers in this assay, from the lowest: compounds 3 and 2 (each within the scatter of the next); then compound 1.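

Within the data shown here, the change from benzyl to 2-chloro-6-fluorobenzyl, with the rest of the shared core untouched, gives in this assay a 250-fold lower number from compound 1 to compound 3 (2.40 log units; beyond the scatter) and is the first comparison here that differs in one place. It shows that substitution on this phenyl, on a saturated chain carbon bound to an amide-type nitrogen in a ring, can alone produce a large drop in the number, with no change elsewhere in compound 1. Nothing measured here bears on why the step is so large.

From the compounds shown here alone, it remains open whether one halogen alone, as in 2-chlorobenzyl or 2-fluorobenzyl, would carry the step or whether both are needed. Also open, going by these compounds, is how methyl or methoxy groups in place of the halogens, or a longer chain in place of the benzyl carbon, would read in this assay.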